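The source may report more compounds than this note shows. Statements on the series, on what has been measured and on what is new or still open speak of the compounds shown alone.

Measured so far:
Compound 1 `COC(=O)NC12CCC(n3cc(-c4ccc(Cl)c(N)c4)c4c(N)ncnc43)(CC1)CC2`: 22 h
Compound 2 `COC(=O)N[C@H]1CC[C@@H](n2cc(-c3ccc(Cl)c(N)c3)c3c(N)ncnc32)CC1`: 3.7 h

In an ADME assay on the whole organism (Mus musculus, strain BALB/c) for metabolic stability, read by LC-MS, at a dose of 10 mg/kg by the oral route (a higher number here means that the compound lasts longer, a lower number that the compound disappears faster), compound 1 gives 22 h, the higher of the two numbers, and the gap to compound 2 at 3.7 h lies beyond the usual scatter. Compound 3 `COC(=O)NC12CCC(n3cc(-c4cc(N)c(Cl)cc4F)c4c(N)ncnc43)(CC1)CC2` has not yet been measured. It keeps the rest of compound 1 and changes in one place: fluoro in place of hydrogen on an aromatic carbon. Put simply, 3-amino-4-chlorophenyl becomes 5-amino-4-chloro-2-fluorophenyl. For the measured compounds named here, no measured pair shows this change, so the data give no direct guide to its size or direction. The starting point is therefore compound 1 at 22 h, and no shift beyond the scatter is expected. The estimated change is a 1.1-fold lower number from compound 1 to compound 3 (0.04 log units; within the scatter). In this assay, compound 3 is expected to give 20 h, with an estimated range from 9 h to 40 h.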

Compound 3, half-life: 19 h
For compound 3 the middle estimate is 1.1-fold (0.02 log units) above the measured one; low and high end bracket the measured number.
By their numbers in this assay, from the lowest: compound 2; then compounds 3 and 1 (each within the scatter of the next).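

In this assay, the step is a 1.2-fold lower number from compound 1 to compound 3 (0.06 log units; within the scatter) and so this aromatic carbon, ortho to a large group and para to the amino group, accepts a fluoro group in place of hydrogen with no change that can be told apart from the usual spread of repeat measurements. For the compounds shown here, compound 3 therefore shows that the long half-life of compound 1 survives this single-atom change, which no earlier pair could show. Nothing at hand explains why the number holds, and no measured information on the cause bears on this result.

On these data alone, whether a larger group at the same carbon, such as methyl, methoxy or a nitrile, would also leave the half-life in place stays open. So does the effect of the same fluoro change on compound 2.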